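Compound 3 to compound 4 at the assay limit

The compounds below may be only part of what the source reports. "The series", "measured", "known", "first", "only" and "open" are said of these compounds alone.

Measured in an ADME assay on HepG2 cells (Homo sapiens) for cytotoxicity, in the presence of a further agent that is not named here (on this read-out higher numbers stand for weaker inhibition and lower numbers for stronger inhibition), each value being a limit of the assay:
Compound 1 `CN(Cc1ccccc1)C(=O)c1nc(Cc2ccccc2C(F)(F)F)n(C)c(=O)c1O` gives > 100000 nM
Compound 2 `Cn1c(Cc2ccccc2C(F)(F)F)nc(C(=O)Nc2ccccc2)c(O)c1=O` gives > 100000 nM
Compound 3 `Cn1c(Cc2ccccc2C(F)(F)F)nc(C(=O)CCc2ccccc2)c(O)c1=O` gives > 100000 nM

Compound 3 therefore stands only at a limit, > 100000 nM, and not at a number. The change to compound 4 `Cn1c(Cc2ccccc2C(F)(F)F)nc(C(=O)NCc2ccccc2F)c(O)c1=O` is (2-fluorobenzyl)amino in place of phenethyl on a carbonyl carbon. Three measured swaps at that same place bear on it: a step that the two limits leave unreadable from compound 1 to compound 2, a step that the two limits leave unreadable from compound 1 to compound 3 and a step that the two limits leave unreadable from compound 2 to compound 3. None of them has a readable size or direction. Given (the limit of > 100000 nM in this assay, at which 3 of the 3 values shown sit), no step beyond the scatter is expected in this assay. The step expected is a number no higher from compound 3 to compound 4 (the limit leaves the size open). For compound 4 the estimated value is 100000 nM, with an expected range of 50000 nM to 200000 nM.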

Compound 4, half-maximal inhibitory concentration: > 100000 nM
Compound 4: a limit, no number; the forecaster's own chance of this, stated with the estimate: 85%; the middle value lies on the limit itself.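

In this assay compound 4 gives > 100000 nM, which is a limit and not a number. Going by these compounds alone, no step from compound 1, compound 2 or compound 3 to compound 4 can be read. The compounds shown leave open whether any change on the carbonyl carbon alters this read-out, and by how much.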